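Removing the ring methyl from compound 2's core

The compounds below may be only part of what the source reports. "The series", "measured", "known", "first", "only" and "open" are said of these compounds alone.

Compound 1 `Cn1cc(C(N)=O)c2c(N)ncnc21` in a functional assay on KB cells (Homo sapiens) for cytotoxicity; on this read-out higher numbers stand for weaker inhibition and lower numbers for stronger inhibition: > 100000 nM, a limit of the assay.
Compound 2 `Cn1cc(C#N)c2c(N)ncnc21` in this assay: > 100000 nM, also a limit.

Both values sit at the limit of > 100000 nM in this assay, at which 2 of the 2 values shown sit, so the step that the two limits leave unreadable from compound 1 to compound 2 cannot be read. Compound 2 therefore stands only at a limit, with no number known. Compound 3 `N#Cc1c[nH]c2ncnc(N)c12` differs from compound 2 by hydrogen in place of methyl on an aromatic nitrogen. No measured step bears on this change, and the only step shown is unreadable. The step of a number no higher from compound 2 to compound 3 (the limit leaves the size open) is expected to stay within scatter. Compound 3 is accordingly expected to give about 100000 nM, between 20000 nM and 300000 nM.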

Compound 3, half-maximal inhibitory concentration: 18000 nM
Compound 3: middle estimate off by 5.6-fold (0.74 log units), on the high side, outside the stated range (below it).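

Hydrogen in place of methyl on the aromatic nitrogen gives an at least 5.5-fold lower number from compound 2 to compound 3 (0.74 log units; beyond the scatter) in this assay, so this position is the first place among the compounds shown where a change registers as a readable shift. Among the compounds shown here, compound 3 is also the only compound here whose value is not a limit. From the compounds shown here alone, the true size of the step stays open, since compound 2 is known only by a limit: the limit of > 100000 nM in this assay, at which 2 of the 3 values shown sit.

Going by these compounds, whether the carbamoyl group of compound 1 would show the same step on losing its methyl remains open. So does how an ethyl group or a longer chain on that nitrogen would read.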